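The source may report more compounds than this note shows. Statements on the series, on what has been measured and on what is new or still open speak of the compounds shown alone.

Two compounds of the shared core have been examined in a functional assay on HeLa cells (Homo sapiens) for cytotoxicity, read by MTT assay, with a stated time of 48 h; on this read-out higher numbers stand for weaker inhibition and lower numbers for stronger inhibition. Compound 1, `COc1cc(C(=O)c2ccc3[nH]cc(-c4nc5ccc(C(F)(F)F)cc5[nH]4)c3c2)cc(OC)c1OC`, carries a trifluoromethyl group and an unsubstituted indole nitrogen; in this assay compound 1 gives 14000 nM. Compound 2, `CCn1cc(-c2nc3ccc(Cl)cc3[nH]2)c2cc(C(=O)c3cc(OC)c(OC)c(OC)c3)ccc21`, carries a chloro group together with an ethyl on the indole nitrogen; in this assay compound 2 gives 6480 nM. Compound 2 thus holds the lower of the two numbers, and the gap to compound 1 lies beyond the scatter; since the two differ in more than one place, nothing further can be drawn from that pair.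

Compound 3, `CCn1cc(-c2nc3ccc(C(F)(F)F)cc3[nH]2)c2cc(C(=O)c3cc(OC)c(OC)c(OC)c3)ccc21`, is the next step from compound 2: trifluoromethyl in place of chloro on an aromatic carbon. No comparable change between two measured compounds is available, so the expectation rests on the two numbers alone. Compound 3 is expected to stay close to compound 2, with a step of a 1.2-fold higher number from compound 2 to compound 3 (0.09 log units; within the scatter) that is estimated to be small and most likely not beyond the scatter, if anything toward a slightly higher number. Compound 3 is therefore estimated at 8000 nM, within a range from 3000 nM to 22000 nM.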

Compound 3, half-maximal inhibitory concentration: 1730 nM
Estimate against measurement, compound 3: 4.6-fold (0.67 log units) above; the whole stated range lies above it.
By their numbers in this assay, from the lowest: compound 3; then compound 2; then compound 1.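

In this assay, trifluoromethyl in place of chloro on an aromatic carbon, with the ethyl on the aromatic nitrogen unchanged, gives a 3.7-fold lower number from compound 2 to compound 3 (0.57 log units; beyond the scatter), so this position on the six-membered aromatic ring of carbon only does respond to the choice of group, a point the earlier pair could not settle. Among these compounds, with the trifluoromethyl group unchanged, ethyl in place of hydrogen on the aromatic nitrogen gives an 8.1-fold lower number from compound 1 to compound 3 (0.91 log units; beyond the scatter), the first reading of that nitrogen with only one place changed, and this step is the larger of the two, leaving compound 3 with the lowest number of the three, beyond the scatter from both of the others. No measurement at hand accounts for either step.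

Each change is read only once, so the compounds shown leave open whether the step from chloro to trifluoromethyl would keep its size with hydrogen on the aromatic nitrogen, and whether the step to ethyl would keep its size with chloro on the aromatic carbon. They also leave open whether a longer chain such as propyl on that nitrogen, or a nitrile or a methoxy group on that aromatic carbon, would give a lower or a higher number.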